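Losing the cyclopropyl on the amide nitrogen of two analogues

A few compounds are considered here, and "the series" means these few. Any claim that something is new, unique, unknown or untested is made for them only; others in the source may bear on it.

Compound 3 `O=C(/C=C1\CCc2c(Cl)cccc21)NC1CC1` and compound 1 `NC(=O)/C=C1\CCc2c(Cl)cccc21` share a core and differ only at the amide nitrogen. In a functional assay on the whole organism with Mus musculus as the target, at a dose of 100 mg/kg by the intraperitoneal route (on this read-out lower numbers stand for less inhibition and higher numbers for more inhibition at the one dose given (going by the name of the read-out)), compound 3 gives 100%, while compound 1 gives 67%, a step of a number 33 percentage points lower from compound 3 to compound 1 (beyond the scatter) for the change (hydrogen in place of cyclopropyl on an amide-type nitrogen). Compound 2 `O=C(/C=C1\CCc2c(F)ccc(F)c21)NC1CC1` is built on a second core; the difference between the two cores is not broken down here. In this assay compound 2 gives 100%, level with compound 3 at the digits shown. Compound 4 `NC(=O)/C=C1\CCc2c(F)ccc(F)c21` repeats on compound 2 the same change, (hydrogen in place of cyclopropyl on an amide-type nitrogen). Because the step from compound 3 to compound 1 was a number 33 percentage points lower from compound 3 to compound 1 (beyond the scatter), the step from compound 2 to compound 4 is expected to be about a number 35 percentage points lower from compound 2 to compound 4 (beyond the scatter). Compound 4 is therefore estimated at 65%, with a range from 40% to 90%.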

Compound 4, a percentage reported as inhibition, in the whole organism at one dose (the size of the read-out at that dose, not a potency): 100%
Estimate against measurement, compound 4: 35 percentage points below; measured number outside the range, above it.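

In this assay, putting hydrogen in place of cyclopropyl on the amide-type nitrogen gives no change at the digits printed from compound 2 to compound 4 (within the scatter). The effect of this change therefore does not carry over unchanged from one core to the other: the same change on two cores in this assay, a number 33 percentage points lower (beyond the scatter) from compound 3 to compound 1 and no change at the digits printed (within the scatter) from compound 2 to compound 4, 33 percentage points apart, beyond the scatter of two such steps This rests on two matched pairs only, and it does not show which difference between the cores accounts for the gap, nor how the change would behave on any third core.

Still open, from the compounds shown here alone, is how a methyl group or a longer chain such as n-butyl on that nitrogen would read on each core. Also open, going by these compounds, is whether compound 2 and compound 4 would still match at a lower dose than the single one given.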